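Iodo for Anilino on the Benzamide Ring

The source may hold more compounds than are shown below. What is called first, only, known or untested is meant among the compounds shown, and "the series" means these compounds.

Compound 1 `CC(/C=N/Nc1ccc([N+](=O)[O-])cc1)=N\NC(=O)c1ccccc1Nc1ccccc1` carries an anilino group on its benzamide ring, and in a functional assay on cells (Splenocyte, Mus musculus, strain BALB/c) for inhibition, read by scintillation counting and thymidine incorporation, with a stated time of 72 h (on this read-out higher numbers stand for weaker inhibition and lower numbers for stronger inhibition), compound 1 is recorded as "not determined" (no result reported), so no single number stands for it. Its relative compound 2 `CC(/C=N/Nc1ccc([N+](=O)[O-])cc1)=N\NC(=O)c1ccc(O)cc1` gives 1510 nM in this assay. Compound 3 `CC(/C=N/Nc1ccc([N+](=O)[O-])cc1)=N\NC(=O)c1ccccc1I` differs from compound 1 by iodo in place of anilino on an aromatic carbon. Among the measured compounds shown here, with compound 1 unmeasured, no step in this assay can be read, and the size and direction of the change remain open; the only anchor is compound 2. Compound 3 is therefore expected to fall near 2000 nM, within a range of 400 nM to 10000 nM.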

Compound 3, half-maximal inhibitory concentration: 2980 nM
The estimate for compound 3 lay 1.5-fold (0.17 log units) below the measured number; the range from low to high includes it.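

In this assay, 2-iodophenyl in place of 4-hydroxyphenyl on a carbonyl carbon gives a 2.0-fold higher number from compound 2 to compound 3 (0.30 log units; within the scatter), so this change separates compound 2 and compound 3 by no more than the scatter. The step from compound 1 to compound 3 cannot be read, and the exchange of anilino for iodo therefore has no measured size or direction. Nothing on hand accounts for this result.

The compounds shown leave open how chloro or an amine would fare on this aromatic carbon. They also leave open whether the iodo group's place matters.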